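A Chain Variant With Thiophene Swapped for Phenyl

This account rests on a few compounds, and the source may have more. Where it says the series, first, only, none or still open, it means among the compounds named here.

Compound 1 `O=C(NCCCCc1cccs1)n1c(=O)oc2ccccc21` is tested in an assay on HEK293 cells for inhibition of acid ceramidase (Homo sapiens), with a stated time of 10 min (on this read-out higher numbers stand for weaker inhibition and lower numbers for stronger inhibition), and gives 37 nM. Compound 2 `O=C(NCCCCc1ccccc1)n1c(=O)oc2cc(Cl)ccc21`, a related compound, gives 33 nM in this assay, so the two values sit within the usual scatter of each other, and compound 1 stands among the highest of the two numbers only in a sense that the measurement cannot confirm. For the measured compounds named here, no two measured compounds differ in a single place, so no step size is known from the data. Compound 3 `O=C(NCCCc1ccccc1)n1c(=O)oc2ccccc21` has not yet been measured. It differs from compound 1 in one place: phenyl in place of (thiophen-2-yl)methyl on a saturated chain carbon, three bonds along the chain from an amide-type nitrogen. Going by the values given here, with no comparable step to lean on, the expectation is drawn only from the values of compound 1 and compound 2, which sit close together. The estimated step of a 1.6-fold higher number from compound 1 to compound 3 (0.21 log units; within the scatter) is expected to be small, with a slight lean toward a higher number, and may fall within the scatter. Compound 3 is therefore estimated at 60 nM, with a plausible range from 20 nM to 200 nM.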

Compound 3, half-maximal inhibitory concentration: 55 nM
Estimate against measurement, compound 3: 1.1-fold (0.04 log units) above, and the stated range covers the measured number.
By their numbers in this assay, from the lowest: compounds 2, 1 and 3 (each within the scatter of the next).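

For the compounds shown here, this is the first pair in the set that differs in only one place, so it gives the first direct look at this position. In this assay the swap of (thiophen-2-yl)methyl for phenyl on a saturated chain carbon gives a 1.5-fold higher number from compound 1 to compound 3 (0.17 log units; within the scatter) and that step lies within the scatter, so the measurement cannot tell the two groups apart. Nothing measured here offers an explanation for this result.

From the compounds shown here alone, whether this position would accept a very different end group, such as an amine or a carboxylic acid, remains open. A single step also cannot separate the effect of changing the ring from that of changing the chain, since the same difference also reads as 2-(thiophen-2-yl)ethyl to benzyl.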